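Bromo for Methoxy: Expected Plasma Binding of Compound 4

The source may hold more compounds than are shown below. What is called first, only, known or untested is meant among the compounds shown, and "the series" means these compounds.

In an ADME assay on a cell-free system (plasma, Mus musculus, strain CD-1) for protein binding, compound 1 `CCCS(=O)(=O)Nc1ccc(Cl)c(C(=O)Nc2cnc3[nH]nc(OC)c3c2)c1F` gives 99.1%, compound 2 `CCCS(=O)(=O)Nc1ccc(Cl)c(C(=O)Nc2cnc3[nH]ncc3c2)c1F` gives 97.1%, and compound 3 `CCCS(=O)(=O)Nc1ccc(F)c(C(=O)Nc2cnc3[nH]nc(OC)c3c2)c1F` gives 97.4%. Compound 3 holds the second highest unbound fraction of the three; its value and that of compound 2 lie within the scatter of each other, while compound 1 is set apart by a 2.9-fold higher unbound fraction from compound 1 to compound 3 (0.46 log units; beyond the scatter). Compound 4 `CCCS(=O)(=O)Nc1ccc(F)c(C(=O)Nc2cnc3[nH]nc(Br)c3c2)c1F` differs from compound 3 by bromo in place of methoxy on an aromatic carbon. Within the data shown here, no measured step exchanges methoxy for bromo. The nearest guides are a 3.2-fold higher unbound fraction from compound 1 to compound 2 (0.51 log units; beyond the scatter), where methoxy also leaves, and a 2.9-fold higher unbound fraction from compound 1 to compound 3 (0.46 log units; beyond the scatter), a change of halogen. Both are modest, so the expected step is a 1.7-fold lower unbound fraction from compound 3 to compound 4 (0.24 log units; within the scatter), a small shift toward more binding, scarcely beyond the scatter. Compound 4 is therefore estimated at 98.5%, within 96.8% to 99.4%.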

Compound 4, plasma protein binding: 98.4%
The estimate for compound 4 lay 1.1-fold (0.03 log units) (unbound fraction) below the measured number; the range from low to high includes it.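

In this assay the exchange gives a 1.6-fold lower unbound fraction from compound 3 to compound 4 (0.21 log units; within the scatter), so on this carbon of the five-membered aromatic ring bromo, with one hydrogen-bond acceptor fewer than methoxy, takes methoxy's place without a shift beyond the scatter. Among these compounds, the only earlier step at this position, a 3.2-fold higher unbound fraction from compound 1 to compound 2 (0.51 log units; beyond the scatter), brought in hydrogen and carried chloro rather than fluoro. Nothing available explains this result.

On these data alone, whether bromo gives a similar step with chloro in place of fluoro remains open. So does the outcome with an amine or a nitrile at this position.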